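The source may report more compounds than this note shows. Statements on the series, on what has been measured and on what is new or still open speak of the compounds shown alone.

Two compounds frame the series in a functional assay on cells (T-cell line, Homo sapiens) for inhibition; a lower number here means a stronger inhibitor, a higher number a weaker inhibitor. Going by the values given here, compound 1 `COc1ccc(CCCN2CCC(COC(c3ccc(Br)cc3)c3ccc(Br)cc3)CC2)cc1` gives 3200 nM, the only true number so far. Compound 2 `CN1CCC(COC(c2ccccc2)c2ccccc2)CC1` gives > 20000 nM in this assay. That value is a limit of the assay and not a number, so compound 2 offers no exact starting point.

Compound 3 `CCCN1CCC(COC(c2ccccc2)c2ccccc2)CC1` is the next case. The change is ethyl in place of hydrogen on a saturated chain carbon bound to an amine nitrogen in a ring, which cut one bond further out reads methyl to propyl. Among the compounds with values here, no measured step gauges this change. The expected a number no higher from compound 2 to compound 3 (the limit leaves the size open) is small, towards stronger inhibition if it moves at all, and quite possibly none beyond the scatter. The estimated value for compound 3 is 20000 nM, with an expected range of 8000 nM to 40000 nM.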

Compound 3, half-maximal inhibitory concentration: 17800 nM
Estimate against measurement, compound 3: 1.1-fold (0.05 log units) above; measured number inside the range.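

At this position, on a saturated chain carbon bound to an amine nitrogen in a ring, the series now has a true number for a compound with a short chain: in this assay compound 3 gives 17800 nM. Compound 2 gives > 20000 nM, which is a limit of the assay and not a number. Ethyl in place of hydrogen, read one bond further out as methyl to propyl, gives an at least 1.1-fold lower number from compound 2 to compound 3 (0.05 log units; that floor lies within the scatter), and the true size of this step stays open because it starts from a limit: the limit of > 20000 nM in this assay, at which 1 of the 3 values shown sits.

Open, from the compounds shown here alone, is whether a longer chain such as butyl, or a benzyl group, at this position moves the number beyond the scatter. Compound 1 differs from compound 3 in more than one place, so the part each of its groups plays in its value cannot be read.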